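The source may report more compounds than this note shows. Statements on the series, on what has been measured and on what is new or still open speak of the compounds shown alone.

Measured compounds:
compound 1 `COc1ccc(-c2ncnn2-c2cc(OC)c(OC)c(OC)c2)cc1` — 120 nM
compound 2 `CCOc1ccc(-c2ncnn2-c2cc(OC)c(OC)c(OC)c2)cc1` — 20 nM
compound 3 `COc1ccccc1-c1ncnn1-c1cc(OC)c(OC)c(OC)c1` — > 10000 nM

In a functional assay on HL-60 cells (Homo sapiens) for antiproliferative activity, read by MTT assay, with a stated time of 72 h (on this read-out lower numbers stand for stronger inhibition and higher numbers for weaker inhibition), compound 1 gives 120 nM. Compound 2 differs from it by methyl in place of hydrogen on a saturated chain carbon bound to an oxygen on an aromatic ring, and the step is a 6.0-fold lower number from compound 1 to compound 2 (0.78 log units; beyond the scatter). Compound 3 differs from compound 1 by 2-methoxyphenyl in place of 4-methoxyphenyl on an aromatic carbon. For compound 3 the value > 10000 nM is a limit of the assay and not a number. The step of an at least 83-fold higher number from compound 1 to compound 3 (1.92 log units; beyond the scatter) therefore only sets a floor, resting on (the limit of > 10000 nM in this assay, at which 1 of the 3 values shown sits).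

Compound 4 `CCOc1ccccc1-c1ncnn1-c1cc(OC)c(OC)c(OC)c1` is not yet measured. It differs from compound 3 by methyl in place of hydrogen on a saturated chain carbon bound to an oxygen on an aromatic ring, the same change that separates compound 1 from compound 2, with the same place on the core. As far as these compounds go, since compound 3 sits at the limit, the starting point for compound 4 is unknown and may lie far past it. The expected step for compound 4 is a step that the limit leaves unreadable from compound 3 to compound 4, taken from the step between compound 1 and compound 2. Compound 4 is expected to give about 12000 nM in this assay. The estimate for compound 4 spans 2000 nM to 60000 nM, and a limit rather than a number is the likelier outcome.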

Compound 4, half-maximal inhibitory concentration: > 10000 nM
Compound 4: only a limit was reported (the forecaster's own chance of this, stated with the estimate: 65%); the middle value does not contradict the limit.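

No step from compound 3 to compound 4 can be read in this assay, since both values are limits of the assay and not numbers: the limit of > 10000 nM in this assay, at which 2 of the 4 values shown sit.

The compounds shown leave open how far past the limit compound 3 and compound 4 lie, and whether methoxy to ethoxy acts on them as it does between compound 1 and compound 2.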